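A few compounds are considered here, and "the series" means these few. Any claim that something is new, unique, unknown or untested is made for them only; others in the source may bear on it.

Compound 1 `CC(C)(CO)CNC(=O)c1cc2cc(C#N)ccc2n1Cc1cccc(OC(F)(F)F)c1`: < 6 mL.min-1.g-1 (a limit)
Compound 2 `CCOc1ccc(OC(F)(F)F)cc1Cn1c(C(=O)NCC(C)(C)CO)cc2cc(C#N)ccc21`: < 6 mL.min-1.g-1 (a limit)
Compound 3 `COc1ccc(Br)cc1Cn1c(C(=O)NCC(C)(C)CO)cc2cc(C#N)ccc21`: < 6 mL.min-1.g-1 (a limit)

All three compounds were tested in an in vitro ADME assay on microsomes from Gut (Homo sapiens) for metabolic stability, using NADPH; on this read-out lower numbers stand for slow clearance and higher numbers for fast clearance. Compound 3 gives < 6 mL.min-1.g-1, which is a limit of the assay and not a number. It therefore has no exact position, and the same is true of the other two compounds: the whole record is the limit of < 6 mL.min-1.g-1 in this assay, at which 3 of the 3 values shown sit.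

The next compound is compound 4 `Cc1ccc(C)c(Cn2c(C(=O)NCC(C)(C)CO)cc3cc(C#N)ccc32)c1`. The change is 2,5-dimethylphenyl in place of 5-bromo-2-methoxyphenyl on a saturated chain carbon bound to an aromatic nitrogen. The shared remainder of the molecule stays as it is.

Within the data shown here, the only measured step that can bear on this is a step that the two limits leave unreadable from compound 1 to compound 2, with ethoxy in place of hydrogen on an aromatic carbon. It offers no size to carry over, yet neither end of it left the limit. Among the measured compounds shown here, no measured compound carries the 2,5-dimethylphenyl group, so the direction of any shift in this assay cannot be told from these data.

The expected change is a step that the limit leaves unreadable from compound 3 to compound 4, so no step beyond the usual scatter is expected. For compound 4 the estimated clearance is 5 mL.min-1.g-1. The expected range for compound 4 runs from 2.5 mL.min-1.g-1 to 12 mL.min-1.g-1.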

Compound 4, intrinsic clearance in microsomes: < 6 mL.min-1.g-1
Compound 4: a limit, no number; the forecaster's own chance of this, stated with the estimate: 75%; the middle value does not contradict the limit.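

Compound 3 and compound 4 both give only a limit and not a number, so no step can be read between them, and the same holds for all the compounds shown: the limit of < 6 mL.min-1.g-1 in this assay, at which 4 of the 4 values shown sit. Still open, as far as these compounds go, is how fast any of them is actually cleared in this assay, and whether any change to the substituted benzyl group would bring a compound clear of that limit.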